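Ethyl for fluorine on the aryl ring: stability expectation

This account rests on a few compounds, and the source may have more. Where it says the series, first, only, none or still open, it means among the compounds named here.

Compound 1, `Cc1ccccc1-c1nc(CN2CCC(C(=O)NCCCN3CCC(C)(C)CC3)CC2)c(C)o1`: > 0.5 h
Compound 2, `Cc1oc(-c2ccc(F)cc2)nc1CN1CCC(C(=O)NCCCN2C[C@H](C)C[C@H](C)C2)CC1`: 0.468 h

Within the data shown here, in an ADME assay on microsomes from liver (Rattus norvegicus) for metabolic stability, read by LC-MS, using NADPH, at 37 degrees C (a higher number here means that the compound lasts longer, a lower number that the compound disappears faster), compound 2 gives 0.468 h, the only number recorded in this set. For compound 1 the result > 0.5 h is a limit of the assay, not a number; (the limit of > 0.5 h in this assay, at which 1 of the 2 values shown sits). Compound 3, `CCc1ccccc1-c1nc(CN2CCC(C(=O)NCCCN3C[C@H](C)C[C@H](C)C3)CC2)c(C)o1`, is not yet measured. It differs from compound 2 by 2-ethylphenyl in place of 4-fluorophenyl on an aromatic carbon. Among the measured compounds shown here, no step between measured compounds is available to size this change, so compound 3 is expected to stay near compound 2, with a step of a 1.2-fold lower number from compound 2 to compound 3 (0.09 log units; within the scatter) not beyond the usual scatter. In this assay the half-life of compound 3 is estimated at 0.38 h, between 0.16 h and 0.85 h.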

Compound 3, half-life: 0.283 h
The estimate for compound 3 lay 1.3-fold (0.13 log units) above the measured number; the range from low to high includes it.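

In this assay, among these compounds, a 1.7-fold lower number from compound 2 to compound 3 (0.22 log units; within the scatter) gives the first step that can be read at this position, and it does not separate the two compounds. 2-Ethylphenyl, with 8 heavy atoms, thus stands in for 4-fluorophenyl, with 7, with no difference beyond the scatter. Nothing shown here gives a cause for this step.

The step changes the substituent and its place on the phenyl ring together, so it cannot assign any share to either. Going by these compounds, how a plain phenyl or a pyridine ring would stand at this position remains open.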